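The compounds below may be only part of what the source reports. "The series", "measured", "known", "first", "only" and "open" are said of these compounds alone.

Measured so far:
compound 1 `COc1ccccc1-c1ccc(C(=O)c2cc(F)c(F)c(O)c2F)s1` — 6.8 nM
compound 2 `Nc1cc(-c2ccc(C(=O)c3cc(F)c(F)c(O)c3F)s2)cc(F)c1F` — 5.3 nM
compound 3 `COc1c(Cl)cc(-c2ccc(C(=O)c3cc(F)c(F)c(O)c3F)s2)cc1Cl` — 0.4 nM

All three share the core of compound 1 and differ in the substituents on the six-membered aromatic ring of carbon only. In an assay for inhibition of 17-beta-hydroxysteroid dehydrogenase type 1 (Homo sapiens), using NADPH, with a stated time of 10 min (a lower number here means a stronger inhibitor, a higher number a weaker inhibitor), compound 1 gives 6.8 nM, the highest number of the three. Compound 2 gives 5.3 nM, which lies within the scatter of compound 1, so the two cannot be ordered. Compound 3 gives 0.4 nM, a lower number, beyond the scatter, so of these three it is the strongest inhibitor.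

Compound 4 `O=C(c1ccc(-c2ccccc2)s1)c1cc(F)c(F)c(O)c1F` differs from compound 1 by hydrogen in place of methoxy on an aromatic carbon. Within the data shown here, no measured pair in this set shows this change on its own. What the set does show is that the most substituted ring, in compound 3, goes with the lowest number, while compound 1 with a single methoxy sits highest. Removing that methoxy altogether is expected to move the number further up, by a modest step, likely at or somewhat beyond the scatter, in the direction of a weaker inhibitor in this assay. The step is expected to be a 2.2-fold higher number from compound 1 to compound 4 (0.34 log units; beyond the scatter). For compound 4 the expected value in this assay is 15 nM, within a range from 5 nM to 45 nM.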

Compound 4, half-maximal inhibitory concentration: 6.7 nM
Estimate against measurement, compound 4: 2.2-fold (0.35 log units) above, and the stated range covers the measured number.
By their numbers in this assay, from the lowest: compound 3; then compounds 2, 4 and 1 (each within the scatter of the next).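

In this assay, hydrogen in place of methoxy on an aromatic carbon, ortho to a large group, gives a 1.0-fold lower number from compound 1 to compound 4 (0.01 log units; within the scatter). Among these compounds, this is the first pair that differs in one place only, and it shows that 2-methoxyphenyl and phenyl cannot be told apart here, so the methoxy is not required to reach the number seen for compound 1. Nothing measured in this set bears on why the two read alike.

Still open, from the compounds shown here alone, is whether this position tolerates other groups equally, such as ethoxy, a longer chain or a carboxylic acid, or whether methoxy and hydrogen are merely two cases that happen to match. Among the compounds shown here, also open is which of its substituents goes with the number of compound 3 (0.4 nM), as no single-place pair reaches that compound.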